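The source may report more compounds than this note shows. Statements on the series, on what has been measured and on what is new or still open speak of the compounds shown alone.

Measured so far:
Compound 1 `CCCCCCCCCCCCNc1nc(SCc2ccc(C(F)(F)F)cc2)nc2ccccc12`: in a functional assay on MCF7 cells (Homo sapiens) for cytotoxicity, read by MTT assay, with a stated time of 72 h (a higher number here means a weaker inhibitor, a lower number a stronger inhibitor), compound 1 gives > 50000 nM, which is a limit of the assay.
Compound 2 `Cc1ccccc1Nc1nc(SCc2ccc(C(F)(F)F)cc2)nc2ccccc12`: compound 2 gives 37500 nM.
Compound 3 `FC(F)(F)c1ccc(CSc2nc(Nc3cccc(Br)c3)c3ccccc3n2)cc1`: compound 3 gives 25600 nM.

Compound 3 sits at the lower of the two numbers shown, but a 1.5-fold lower number from compound 2 to compound 3 (0.17 log units; within the scatter) is within the scatter, so the two are not separated; the remaining value is only a limit (the limit of > 50000 nM in this assay, at which 1 of the 3 values shown sits).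

Compound 4 `COc1cc(Nc2nc(SCc3ccc(C(F)(F)F)cc3)nc3ccccc23)cc(OC)c1` is not yet measured. Its change from compound 3: 3,5-dimethoxyphenyl in place of 3-bromophenyl on a nitrogen on an aromatic ring. Among the measured compounds shown here, the single step that bears on it, a 1.5-fold lower number from compound 2 to compound 3 (0.17 log units; within the scatter), also swaps the group on a nitrogen on an aromatic ring and stays within the scatter, so for compound 4 no step beyond the scatter is expected in either direction. Compound 4 is expected at 25000 nM (range 8000 nM to 80000 nM). This amounts to an estimated step of a 1.0-fold lower number from compound 3 to compound 4 (0.01 log units; within the scatter).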

Compound 4, half-maximal inhibitory concentration: 6990 nM
The estimate for compound 4 lay 3.6-fold (0.55 log units) above the measured number; the whole stated range lies above it.
By their numbers in this assay, from the lowest: compound 4; then compounds 3 and 2 (each within the scatter of the next). At a limit, above all of these: compound 1.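

Here the group on the nitrogen moves the number beyond the scatter, which the step from 2-methylphenyl to 3-bromophenyl did not do. With 3,5-dimethoxyphenyl in that place, the data show a 3.7-fold lower number from compound 3 to compound 4 (0.56 log units; beyond the scatter) and also a 5.4-fold lower number from compound 2 to compound 4 (0.73 log units; beyond the scatter), both modest in size. Nothing measured here accounts for these steps.

On these data alone, it remains open whether both methoxy groups are needed for the lower number. Also open, as far as these compounds go, is whether a single methoxy group, a hydroxyl or an amine at that ring would give a similar step.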